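Cyclohexyl Ester Returns to a Methyl-Bearing Core

The source may report more compounds than this note shows. Statements on the series, on what has been measured and on what is new or still open speak of the compounds shown alone.

Measured compounds:
- Compound 1, `CCCCc1nc(C(C)C)c(CC(=O)OC2CCCCC2)c(=O)n1Cc1ccc(-c2ccccc2-c2noc(=O)[nH]2)cc1`: 13.3%
- Compound 2, `CCCCOC(=O)Cc1c(C)nc(CCCC)n(Cc2ccc(-c3ccccc3-c3noc(=O)[nH]3)cc2)c1=O`: 2.8%

In an ADME assay on microsomes from liver (Homo sapiens) for metabolic stability, with a stated time of 30 min (on this read-out lower numbers stand for a less stable compound and higher numbers for a more stable compound), compound 2 gives 2.8%, the lower of the two numbers in hand. Compound 1, in the same this assay, gives 13.3%, a value that lies beyond the usual scatter above compound 2; the two structures differ in more than one place, so no single change can be read from them.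

Compound 3, `CCCCc1nc(C)c(CC(=O)OC2CCCCC2)c(=O)n1Cc1ccc(-c2ccccc2-c2noc(=O)[nH]2)cc1`, is not yet measured in this assay. It is reached from compound 2 by cyclohexyl in place of butyl on an oxygen next to a carbonyl group, so that compound 3 carries the same cyclohexyl ester as compound 1. Because compound 1 gives 13.3% with that ester, a modest upward step is expected, though one that may stay within the scatter. The expected step is a number 4.2 percentage points higher from compound 2 to compound 3 (within the scatter). Compound 3 is estimated at 7%, with a range from 1.5% to 18%.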

Compound 3, percent of the compound remaining: 3.9%
For compound 3 the middle estimate is 3.1 percentage points above the measured one; the measured number falls inside the stated range.
By their numbers in this assay, from the lowest: compounds 2, 3 and 1 (each within the scatter of the next, the first and the last beyond it).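

In this assay the exchange of butyl for cyclohexyl on an oxygen next to a carbonyl group gives a number 1.1 percentage points higher from compound 2 to compound 3 (within the scatter), so on the methyl-bearing core this ester change has no effect that can be told from the scatter. Methyl in place of isopropyl on an aromatic carbon gives a number 9.4 percentage points lower from compound 1 to compound 3 (within the scatter), so this first single-place comparison with compound 1 also cannot be told from the scatter, even though compound 1 and compound 2 lie beyond the scatter of each other. No measurement in hand accounts for either step.

As far as these compounds go, it remains open whether an amide or a carboxylic acid in place of the ester would give a different number in this assay. Also open, from the compounds shown here alone, is how ethyl or a longer chain on that aromatic carbon would read.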